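The source may report more compounds than this note shows. Statements on the series, on what has been measured and on what is new or still open speak of the compounds shown alone.

In a physicochemical assay for solubility, with a stated time of 24 h, tested at 30 mg/mL (a higher number here means a more soluble compound, a lower number a less soluble compound), compound 2 (`Cc1cc(COc2ccc(S(=O)(=O)NCCC(=O)NO)cc2)c2ccccc2n1`) gives 4100000 nM. Compound 1 (`CC(=O)N1CC(CC(=O)NO)(NS(=O)(=O)c2ccc(OCc3cc(C)nc4ccccc34)cc2C)C1`) gives 900000 nM, so compound 2 is the higher of these two, by a gap beyond the usual scatter. Compound 3 (`Cc1cc(COc2ccc(S(=O)(=O)NC3(CC(=O)NO)CCN(C(=O)CC(C)C)C3)cc2)c2ccccc2n1`) has two entries rather than a single number, 17000000 nM; 7900000 nM (2 entries). Compound 4 (`Cc1cc(COc2ccc(S(=O)(=O)NC3(C(=O)NO)CCCC3)cc2)c2ccccc2n1`) is still unmeasured, and its difference from compound 2 is a group of 9 heavy atoms (6 carbon, 1 nitrogen, 2 oxygen; one five-membered non-aromatic ring of carbon only) in place of a group of 6 heavy atoms (3 carbon, 1 nitrogen, 2 oxygen; no ring), on a sulfonamide nitrogen. Going by the values given here, no measured pair isolates this change. A moderate fall in this assay is expected, since compound 1, with a ring on the sulfonamide nitrogen side, gives 900000 nM, though compound 3, also ringed there, goes against this with 17000000 nM; 7900000 nM (2 entries). The expected change is a 2.1-fold lower number from compound 2 to compound 4 (0.31 log units; beyond the scatter). Compound 4 is estimated at 2000000 nM, with an expected range of 500000 nM to 8000000 nM.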

Compound 4, solubility: 200000 nM
For compound 4 the middle estimate is 10-fold (1.00 log units) above the measured one; the whole stated range lies above it.
By their numbers in this assay, from the lowest: compound 4; then compound 1; then compound 2.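

In this assay, the sulfonamide nitrogen emerges as a position where the substituent can strongly shift the number: replacing the 2-(hydroxycarbamoyl)ethyl group with the group bearing a five-membered carbon ring gives a 21-fold lower number from compound 2 to compound 4 (1.31 log units; beyond the scatter). A ring at this position does not by itself bring so low a number, and compound 3, also ringed there, goes against any such pattern: the several entries of compound 3 in this assay, 17000000 nM; 7900000 nM (2 entries)

The compounds shown do not separate the contribution of the carbon ring from that of the rest of the entering group. They also leave open how an amine or a carboxylic acid on that ring would read in this assay.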